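The compounds below may be only part of what the source reports. "The series", "measured", "known", "first", "only" and "open" are said of these compounds alone.

Measured compounds:
Compound 1 `CN1CCC(COC(c2ccccc2)c2ccccc2)CC1` gives > 20000 nM in a functional assay on cells (T-cell line, Homo sapiens) for inhibition (on this read-out higher numbers stand for weaker inhibition and lower numbers for stronger inhibition), a limit of the assay and not a number.
Compound 2 `COc1ccccc1CCCN1CCC(COC(c2ccccc2)c2ccccc2)CC1` gives 2400 nM in this assay.
Compound 3 `CCN1CCC(COC(c2ccccc2)c2ccccc2)CC1` gives > 20000 nM in this assay, again a limit and not a number.

Compound 1 therefore stands only at that limit, where two of the three values shown sit (the limit of > 20000 nM in this assay, at which 2 of the 3 values shown sit). The unmeasured compound 4 `C(#Cc1ccccc1)CN1CCC(COC(c2ccccc2)c2ccccc2)CC1` differs from compound 1 by 2-phenylethynyl in place of hydrogen on a saturated chain carbon bound to an amine nitrogen in a ring. Among the measured compounds shown here, one measured step bears on this change: an at least 8.3-fold lower number from compound 1 to compound 2 (0.92 log units; beyond the scatter), where a larger group entered at the same place. The step that the two limits leave unreadable from compound 1 to compound 3 gives no readable size. A step of similar direction, towards a lower number, is expected for compound 4. Compound 4 is estimated at 5000 nM, between 1500 nM and 20000 nM, which would mean an at least 4.0-fold lower number from compound 1 to compound 4 (0.60 log units; beyond the scatter) as the expected step.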

Compound 4, half-maximal inhibitory concentration: > 20000 nM
Compound 4 ended at the assay's limit (the forecaster's own chance of this, stated with the estimate: 30%); middle value at least 4.0-fold (0.60 log units) from the limit.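

Putting 2-phenylethynyl in place of 2-(2-methoxyphenyl)ethyl gives an at least 8.3-fold higher number from compound 2 to compound 4 (0.92 log units; beyond the scatter), so in this assay a phenyl ring carried on this chain is not enough by itself to bring a value below the limit. The steps among compound 1, compound 3 and compound 4 cannot be read. Compound 4 stands at a limit of the assay, not a number, and compound 2 remains the only compound with a measured value: the limit of > 20000 nM in this assay, at which 3 of the 4 values shown sit.

On these data alone, it remains open whether the methoxy group or the saturated chain of compound 2 accounts for this difference. A plain 3-phenylpropyl group, or an amine at the end of a longer chain, would bear on that question.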